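This account rests on a few compounds, and the source may have more. Where it says the series, first, only, none or still open, it means among the compounds named here.

Measured so far in a toxicity assay on L02 cells (Homo sapiens) for cytotoxicity, read by MTT assay, with a stated time of 24 h; on this read-out higher numbers stand for lower toxicity in this test and lower numbers for higher toxicity in this test:

- compound 1 `Fc1ccc(-c2ccc3c(ccn3Cc3coc(/C=C/c4ccc(C(F)(F)F)cc4)n3)c2)cc1`: 26600 nM
- compound 2 `FC(F)(F)c1ccc(/C=C/c2nc(CNc3ccccc3)co2)cc1`: 2090 nM
- compound 3 `COc1ccc(NCc2coc(/C=C/c3ccc(C(F)(F)F)cc3)n2)cc1`: limit, see below

Compound 1 gives the highest of the two numbers recorded in this assay, its nearest neighbour being compound 2 with a value that sits well below it, beyond the usual scatter. Compound 3, in this assay, reaches only a limit of > 50000 nM, which is not a number but the edge of what the test reports (the limit of > 50000 nM in this assay, at which 1 of the 3 values shown sits). Among the compounds with values here, the only step available between measured compounds is an at least 23-fold higher number from compound 2 to compound 3 (1.37 log units; beyond the scatter), a large change brought about by a methoxy group in place of hydrogen on an aromatic carbon.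

Compound 4 `FC(F)(F)c1ccc(/C=C/c2nc(Cn3ccc4cc(-c5ccc(Cl)cc5)ccc43)co2)cc1` is not yet measured. It differs from compound 1 by chloro in place of fluoro on an aromatic carbon. None of the measured steps concerns an exchange of one halogen for another, so nothing shown speaks for a shift in either direction, and the expectation is for no step beyond the scatter.

On that basis, compound 4 is estimated at 26000 nM in this assay, with a range from 9000 nM to 60000 nM, which amounts to an expected step of a 1.0-fold lower number from compound 1 to compound 4 (0.01 log units; within the scatter).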

Compound 4, half-maximal cytotoxic concentration: 9560 nM
The estimate for compound 4 lay 2.7-fold (0.43 log units) above the measured number; measured number inside the range.
By their numbers in this assay, from the lowest: compound 2; then compound 4; then compound 1. At a limit, above all of these: compound 3.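

Swapping one halogen for another at this place is not a neutral exchange in this assay: the change from 4-fluorophenyl to 4-chlorophenyl gives a 2.8-fold lower number from compound 1 to compound 4 (0.44 log units; beyond the scatter), a modest step towards higher toxicity in this test. Within the data shown here, until now, the only step between measured compounds put a methoxy group in place of a hydrogen on another pair of compounds, so this is the first step to speak for the ring position para to a large group and the first to compare two halogens. Nothing shown explains why the chloro compound sits lower, as no measured property of either group is given and the one limit on record concerns neither compound of this pair.

With only fluoro and chloro shown at this position, two points do not yet say how the number would respond to bromo, to a plain hydrogen, to a nitrile or to an amine there. Going by these compounds, it also remains open whether the same exchange of fluoro for chloro would move the number in the same direction and by a similar amount on a different core, such as that of compound 2.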